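The source may report more compounds than this note shows. Statements on the series, on what has been measured and on what is new or still open speak of the compounds shown alone.

Compound 1 `CN(C(=O)NC(=O)c1cccc(C(F)(F)F)c1)c1nc(C(F)(F)F)c(C(=O)N/N=C/c2cccc(C(F)(F)F)c2)s1`: 4.6 ug/mL
Compound 2 `CN(C(=O)NC(=O)c1ccc([N+](=O)[O-])cc1)c1nc(C(F)(F)F)c(C(=O)N/N=C/c2cccc(C(F)(F)F)c2)s1`: 1.67 ug/mL
Compound 3 `CN(C(=O)NC(=O)c1ccc(F)c(F)c1)c1nc(C(F)(F)F)c(C(=O)N/N=C/c2ccc(C(F)(F)F)cc2)s1`: 3.85 ug/mL

These three compounds were tested in a functional assay on BCG823 cells (Homo sapiens) for inhibition, read by MTT assay, with a stated time of 72 h; a lower number here means a stronger inhibitor, a higher number a weaker inhibitor. Compound 2 stands lowest of the three numbers; compound 3 comes nearest and compound 1 furthest, both gaps beyond the scatter. Compound 4 `CN(C(=O)NC(=O)c1ccc([N+](=O)[O-])cc1)c1nc(C(F)(F)F)c(C(=O)N/N=C/c2ccc([N+](=O)[O-])cc2)s1` has not been measured; it differs from compound 2 in one place: 4-nitrophenyl in place of 3-(trifluoromethyl)phenyl on a carbon with a double bond to nitrogen. Among the measured compounds shown here, one measured step bears on this change. The step of a 2.8-fold lower number from compound 1 to compound 2 (0.44 log units; beyond the scatter) made the same exchange, 4-nitrophenyl in place of 3-(trifluoromethyl)phenyl, but on a carbonyl carbon rather than on a carbon with a double bond to nitrogen. For the measured compounds named here, no step at that second place has been measured. A modest lowering is therefore expected, a 1.4-fold lower number from compound 2 to compound 4 (0.14 log units; within the scatter), though a result within the scatter would not surprise. Compound 4 is estimated at 1.2 ug/mL, within 0.5 ug/mL to 3 ug/mL.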

Compound 4, half-maximal inhibitory concentration: 7.45 ug/mL
Compound 4: middle estimate off by 6.2-fold (0.79 log units), on the low side, and the stated range ends below it.
By their numbers in this assay, from the lowest: compound 2; then compounds 3, 1 and 4 (each within the scatter of the next).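

In this assay, 4-nitrophenyl in place of 3-(trifluoromethyl)phenyl on a carbon with a double bond to nitrogen gives a 4.5-fold higher number from compound 2 to compound 4 (0.65 log units; beyond the scatter). On a carbonyl carbon the same exchange went the other way, with a 2.8-fold lower number from compound 1 to compound 2 (0.44 log units; beyond the scatter), so among these compounds its outcome depends on where it is made. No measurement at hand explains this reversal. On these data alone, it remains open whether the rise follows from the arrival of 4-nitrophenyl or the departure of 3-(trifluoromethyl)phenyl, and how an unsubstituted phenyl or a 4-aminophenyl would read at this place.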